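A few compounds are considered here, and "the series" means these few. Any claim that something is new, unique, unknown or untested is made for them only; others in the source may bear on it.

The series shares one core, seen in compound 1 `Cc1cc(C)cc(Oc2cccc(-c3c(C)nnn3C3CCN(C(=N)N)CC3)n2)c1`, compound 2 `Cc1cc(C)cc(Oc2nccc(-c3c(C)nnn3C3CCN(C(=N)N)CC3)n2)c1` and compound 3 `Cc1cc(C)cc(Oc2cccc(-c3c(C)nnn3C3CCNCC3)n2)c1`. In a functional assay on MM1.S cells (Homo sapiens) for antiproliferative activity, read by resazurin assay, with a stated time of 69 h (a lower number here means that less compound is needed, a higher number that more compound is needed for the effect), compound 1 gives > 50000 nM, which is a limit of the assay and not a number. Compound 2 likewise gives > 50000 nM in this assay, again only a limit. Within the data shown here, compound 3 gives 2900 nM and so stands as the only numeric value shown. The two other compounds sit at the limit (the limit of > 50000 nM in this assay, at which 2 of the 3 values shown sit). Among the measured compounds shown here, the one comparable step runs from compound 1 to compound 3, where a hydrogen atom replaces a group of 3 heavy atoms on an amine nitrogen in a ring and gives an at least 17-fold lower number from compound 1 to compound 3 (1.23 log units; beyond the scatter).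

Compound 4 `Cc1cc(C)cc(Nc2cccc(-c3c(C)nnn3C3CCNCC3)n2)c1` differs from compound 3 in another place: (3,5-dimethylphenyl)amino in place of 3,5-dimethylphenoxy on an aromatic carbon. For the measured compounds named here, no measured step touches this part of the molecule, and the step from compound 1 to compound 3 concerns the ring amine, so it gives no direction for the change at the aromatic carbon. The expectation for this assay is therefore a step of no size beyond the scatter, no change at the digits printed from compound 3 to compound 4 (within the scatter). Compound 4 is thus estimated at 2900 nM, with a range from 700 nM to 12000 nM.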

Compound 4, half-maximal effective concentration: 6300 nM
Compound 4: middle estimate off by 2.2-fold (0.34 log units), on the low side; low and high end bracket the measured number.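

In this assay, among these compounds, the change from 3,5-dimethylphenoxy to (3,5-dimethylphenyl)amino on the aromatic carbon next to the ring nitrogen gives a 2.2-fold higher number from compound 3 to compound 4 (0.34 log units; beyond the scatter), the first measured step at this position, and it shows that the number here responds to the atom joining the 3,5-dimethylphenyl ring to the core. The step is modest but beyond the scatter, and since both compounds give true numbers rather than a limit, the entering group, with a hydrogen-bond donor that the leaving group lacks, keeps the compound within the measurable range of the assay. Nothing measured here accounts for the direction of this step, so no cause can be given for it.

The compounds shown leave open how a methylene or a sulfur link at this position would compare with the oxygen and amino links, and whether the same step would hold with a methyl group on the ring amine. From the compounds shown here alone, the steps among the compounds that sit at the limit cannot be read, so the effect of the extra ring nitrogen in compound 2 also stays open.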